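Amide Substituent Changes on a Shared Vitamin D Receptor Scaffold

This account rests on a few compounds, and the source may have more. Where it says the series, first, only, none or still open, it means among the compounds named here.

Measured compounds:
compound 1, `CCN(CC)CCNC(=O)c1ccc(C(CC)(CC)c2ccc(OCC(O)C(C)(C)C)c(C)c2)n1CC`: 110 nM
compound 2, `C=CCN(C)C(=O)c1ccc(C(CC)(CC)c2ccc(OCC(O)C(C)(C)C)c(C)c2)n1CC`: 3950 nM

Compound 2 gives the highest of the two numbers in an assay on HL-60 cells for agonist activity at vitamin D3 receptor (Homo sapiens), read by microscopy, with a stated time of 96 h; on this read-out higher numbers stand for an effect only at larger amounts of compound and lower numbers for an effect already at smaller amounts; compound 1 has the lower number, and the step of a 36-fold higher number from compound 1 to compound 2 (1.56 log units; beyond the scatter) lies beyond the scatter. The next compound, compound 3, `CCOc1ccc(NC(=O)c2ccc(C(CC)(CC)c3ccc(OCC(O)C(C)(C)C)c(C)c3)n2CC)cc1`, differs from compound 2 by (4-ethoxyphenyl)amino in place of allyl(methyl)amino on a carbonyl carbon. For the measured compounds named here, only the step from compound 1 to compound 2 bears on this change, and it was large, showing that the group on the carbonyl carbon strongly governs this assay. Compound 3 brings back a hydrogen-bond donor, so a lower number is expected, estimated as a 6.6-fold lower number from compound 2 to compound 3 (0.82 log units; beyond the scatter). Compound 3 is estimated at 600 nM, between 100 nM and 4000 nM.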

Compound 3, half-maximal effective concentration: 630 nM
Beside the measured number, compound 3's estimate is 1.1-fold (0.02 log units) below it; the measured number falls inside the stated range.
By their numbers in this assay, from the lowest: compound 1; then compound 3; then compound 2.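

In this assay, the (4-ethoxyphenyl)amino group gives a 6.3-fold lower number from compound 2 to compound 3 (0.80 log units; beyond the scatter), so a tertiary amide is not needed for a number well under that of compound 2. An aromatic group on the amide-type nitrogen still falls short of 2-(diethylamino)ethyl, with a 5.7-fold higher number from compound 1 to compound 3 (0.76 log units; beyond the scatter). Nothing measured here explains either step. The compounds shown leave open whether the gain depends on the amide hydrogen, which a methyl group on that nitrogen in compound 3 would test. They also leave open how a carboxylic acid or a morpholine on the amide chain would read.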